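Piperazine amides of the shared core and an inactive pair

The compounds below may be only part of what the source reports. "The series", "measured", "known", "first", "only" and "open" are said of these compounds alone.

Measured compounds:
- compound 1, `COc1ccc(C(=O)NCCNc2nc3cc(C)cc(C)c3cc2C#N)nc1`: 2700 nM
- compound 2, `Cc1cc(C)c2cc(C#N)c(N3CCN(C(=O)c4ccccn4)CC3)nc2c1`: "not active" (no number reported)
- compound 3, `Cc1cc(C)c2cc(C#N)c(N3CCN(C(=O)c4cccnc4)CC3)nc2c1`: "not active" (no number reported)

In an in vitro assay on FRT cells with Cystic fibrosis transmembrane conductance regulator variant F508del (Homo sapiens) as the target, read by fluorescence, with a stated time of 24 h, at 37 degrees C, in the presence of a further agent that is not named here (a lower number here means that less compound is needed, a higher number that more compound is needed for the effect), compound 1 gives 2700 nM. Compound 2 is reported in this assay as "not active" (no number reported), without a number. Compound 3 stands in the same place: in this assay compound 3 is reported as "not active" (no number reported), again with no number, so it carries no figure against which a step could be sized. Compound 4, `Cc1cc(C)c2cc(C#N)c(N3CCN(C(=O)c4ccncc4)CC3)nc2c1`, differs from compound 3 only in pyridin-4-yl in place of pyridin-3-yl on a carbonyl carbon. Going by the values given here, with no measured step to lean on, and with compound 2 and compound 3 both showing no activity, the expectation is no gain beyond the scatter. Compound 4 is therefore estimated at 15000 nM, within 4000 nM to 50000 nM, most likely reported again without a number.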

Compound 4, half-maximal effective concentration: "not active" (no number reported)
Compound 4: no number reported; there is nothing to compare the estimate with.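

Compound 3 and compound 4 both come without a number, so no step can be read between them, and no supporting evidence bears on this result. The compounds shown leave open whether pyridin-3-yl or pyridin-4-yl on the carbonyl makes any difference.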